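Methyl in place of methoxy on the anilino ring

The compounds below may be only part of what the source reports. "The series", "measured", "known", "first", "only" and "open" are said of these compounds alone.

Compound 1 `COc1ccc(Nc2nc(SCc3cn(Cc4ccccc4Cl)nn3)nc(-c3ccccc3)c2C#N)cc1` gives 8050 nM in a functional assay on MCF7 cells (Homo sapiens) for inhibition, read by MTT assay, with a stated time of 72 h; a lower number here means a stronger inhibitor, a higher number a weaker inhibitor.
Compound 2 `N#Cc1c(Nc2ccccc2)nc(SCc2cn(Cc3ccccc3Cl)nn2)nc1-c1ccccc1` gives > 64000 nM, a limit of the assay.
Compound 3 `Cc1ccc(Nc2nc(SCc3cn(Cc4ccc(Cl)cc4)nn3)nc(-c3ccccc3)c2C#N)cc1` gives > 64000 nM, a limit of the assay.

Among the three measured compounds, compound 1 stands as the only one with a number rather than a limit. Compound 4 `Cc1ccc(Nc2nc(SCc3cn(Cc4ccccc4Cl)nn3)nc(-c3ccccc3)c2C#N)cc1` has not yet been measured; it differs from compound 1 by methyl in place of methoxy on an aromatic carbon.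

For the measured compounds named here, one measured step bears on this change: an at least 7.9-fold higher number from compound 1 to compound 2 (0.90 log units; beyond the scatter), in which the methoxy is taken away entirely. That step reached the limit (the limit of > 64000 nM in this assay, at which 2 of the 3 values shown sit), so the loss was at least modest and may be larger. Going by the values given here, compound 3 also carries a methyl, though together with a change in the chlorobenzyl group, and it sits at the same limit; no single-point step links it to compound 1. Taking the methyl as a partial return toward the unsubstituted ring, a weakening in this assay is expected, of roughly a 3.7-fold higher number from compound 1 to compound 4 (0.57 log units; beyond the scatter). The estimate for compound 4 is therefore 30000 nM, within 8000 nM to 110000 nM.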

Compound 4, half-maximal inhibitory concentration: 9420 nM
For compound 4 the middle estimate is 3.2-fold (0.50 log units) above the measured one; measured number inside the range.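

In this assay, methyl and methoxy at this position cannot be told apart, with a 1.2-fold higher number from compound 1 to compound 4 (0.07 log units; within the scatter), so the oxygen of the methoxy is not needed here. The change from hydrogen to methyl gives an at least 6.7-fold lower number from compound 2 to compound 4 (0.83 log units; beyond the scatter), which shows that the loss seen in compound 2 is not tied to methoxy alone, since either group on this carbon gives a measurable number. Going by these compounds, compound 3 carries the same methyl yet goes against this pattern, with the place of the chlorine giving an at least 6.7-fold lower number from compound 3 to compound 4 (0.83 log units; beyond the scatter), and both of these steps start from a limit of the assay, so their full size stays unknown: the limit of > 64000 nM in this assay, at which 2 of the 4 values shown sit.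

The compounds shown leave open whether an amine or a longer chain such as ethoxy on this carbon would give a similar number. They also leave open whether methoxy could restore a measurable number with the 4-chlorophenyl group.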